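The source may hold more compounds than are shown below. What is called first, only, known or untested is meant among the compounds shown, and "the series" means these compounds.

Measured so far:
Compound 1, `COc1ccc(-c2nn(-c3ccc(Cl)cc3)cc2/C=N\c2ccccc2)cc1`, gives 72.6% in a functional assay on the whole organism (strain Wistar albino) for inhibition, with Rattus norvegicus as the target, read by paw edema, with stated times of 1 h and 3 h, at a dose of 0.32 mmol/kg by the intraperitoneal route; a lower number here means less inhibition, a higher number more inhibition at the dose given (going by the name of the read-out).
Compound 2, `COc1ccc(/N=C\c2cn(-c3ccc(Cl)cc3)nc2-c2ccc(OC)cc2)cc1`, gives 82.2% in this assay.

On these two numbers compound 2 stands highest, with compound 1 nearest at a distance within the scatter, so no order between the two can be claimed. The step of a number 9.6 percentage points higher from compound 1 to compound 2 (within the scatter) came from a methoxy in place of hydrogen on an aromatic carbon.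

Compound 3, `COc1ccc(-c2nn(-c3ccc(Cl)cc3)cc2/C=N\c2ccc(Cl)cc2)cc1`, is not yet measured. Its change from compound 2 is chloro in place of methoxy on an aromatic carbon. Going by the values given here, the only measured step that bears on it is a number 9.6 percentage points higher from compound 1 to compound 2 (within the scatter), which concerns the same aromatic carbon and stayed within the scatter; exchanging the substituent there has so far not moved the read-out beyond repeat variation. In this assay the expected step is therefore a number 4.2 percentage points lower from compound 2 to compound 3 (within the scatter), none beyond the scatter. Compound 3 is estimated at 78%, within 64% to 90%.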

Compound 3, a percentage reported as inhibition, in the whole organism at one dose (the size of the read-out at that dose, not a potency): 72.6%
Estimate against measurement, compound 3: 5.4 percentage points above; measured number inside the range.
By their numbers in this assay, from the lowest: compounds 1, 3 and 2 (each within the scatter of the next).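

In this assay, the exchange of 4-methoxyphenyl to 4-chlorophenyl gives a number 9.6 percentage points lower from compound 2 to compound 3 (within the scatter), while chloro in place of hydrogen on the same aromatic carbon gives no change at the digits printed from compound 1 to compound 3 (within the scatter). Going by these compounds alone, this carbon, para to a large group, has now carried hydrogen, methoxy and chloro, and no step among the three lies beyond the scatter, so the series supports no ranking of these substituents. No accompanying measurement bears on the reason for this result.

Going by these compounds, whether an amine, a carboxylic acid or a longer alkoxy chain on this carbon would give a step beyond the scatter remains open. Also open, on these data alone, is whether these three compounds would separate at another dose, since a reading at one dose gives no potency.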